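Anilinopyrimidine series: aniline variation and antiproliferative potency

The source may report more compounds than this note shows. Statements on the series, on what has been measured and on what is new or still open speak of the compounds shown alone.

Measured compounds:
compound 1, `CNC(=O)c1ccccc1Oc1nc(Nc2ccc(Br)cc2)ncc1Br`, > 50000 nM in a functional assay on MCF7 cells (Homo sapiens) for antiproliferative activity, read by MTT assay, with a stated time of 24 h (a lower number here means a stronger inhibitor, a higher number a weaker inhibitor), a limit of the assay
compound 2, `CNC(=O)c1ccccc1Oc1nc(Nc2cccc(C)c2)ncc1Br`, 16600 nM
compound 3, `CNC(=O)c1ccccc1Oc1nc(Nc2ccc(C)cc2C)ncc1Br`, 44700 nM

Compound 1 sits at the limit (the limit of > 50000 nM in this assay, at which 1 of the 3 values shown sits). Among the two numbers, compound 3 stands highest; the only comparable step is a 2.7-fold higher number from compound 2 to compound 3 (0.43 log units; beyond the scatter). Compound 4, `CNC(=O)c1ccccc1Oc1nc(Nc2cccc(C(C)C)c2)ncc1Br`, differs from compound 3 by 3-isopropylphenyl in place of 2,4-dimethylphenyl on a nitrogen on an aromatic ring. This returns the pattern to a single substituent, as in compound 2, so the step from compound 3 is expected to run back down by roughly the size of a 2.7-fold higher number from compound 2 to compound 3 (0.43 log units; beyond the scatter), in the opposite direction. The expected step is a 2.2-fold lower number from compound 3 to compound 4 (0.35 log units; beyond the scatter). Compound 4 is therefore estimated at 20000 nM, within 7000 nM to 60000 nM.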

Compound 4, half-maximal inhibitory concentration: 26500 nM
For compound 4 the middle estimate is 1.3-fold (0.12 log units) below the measured one, and the stated range covers the measured number.
By their numbers in this assay, from the lowest: compounds 2, 4 and 3 (each within the scatter of the next, the first and the last beyond it). At a limit, above all of these: compound 1.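

In this assay, isopropyl in place of methyl on an aromatic carbon gives a 1.6-fold higher number from compound 2 to compound 4 (0.20 log units; within the scatter), so this change leaves no readable difference. The change from 2,4-dimethylphenyl to 3-isopropylphenyl gives a 1.7-fold lower number from compound 3 to compound 4 (0.23 log units; within the scatter), so compound 4 cannot be separated from either neighbour, even though the step between those two neighbours lies beyond the scatter. The remaining step is an at least 1.8-fold lower number from compound 1 to compound 4 (0.27 log units; that floor lies within the scatter). It gives only a floor, because the value of compound 1 is a limit: the limit of > 50000 nM in this assay, at which 1 of the 4 values shown sits.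

Open, going by these compounds, is whether an amine or a methoxy group in place of the isopropyl would move the number beyond the scatter of compound 2. On these data alone, a longer chain at this place is equally open.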